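The compounds below may be only part of what the source reports. "The series", "measured", "known", "first", "only" and "open" are said of these compounds alone.

Measured compounds:
Compound 1, `CC(C)n1nc(-c2ccc3oc(N)nc3c2)c2c(Cl)nc(N)nc21`: 11 uL/min
Compound 2, `CC(C)n1nc(-c2ccc3oc(N)nc3c2)c2c(C#N)nc(N)nc21`: < 5 uL/min

Compound 1, with structure `CC(C)n1nc(-c2ccc3oc(N)nc3c2)c2c(Cl)nc(N)nc21`, gives 11 uL/min in an ADME assay on cells (Hepatocyte, Homo sapiens) for metabolic stability, read by LC-MS, with a stated time of 90 min, tested at 1 uM; a lower number here means slower removal, a higher number faster removal of the compound. Compound 2, `CC(C)n1nc(-c2ccc3oc(N)nc3c2)c2c(C#N)nc(N)nc21`, reaches the limit of this assay, returning < 5 uL/min rather than a number. Compound 2 therefore stands at the limit of < 5 uL/min in this assay, at which 1 of the 2 values shown sits, and only that limit is known for it. Going by the values given here, the single measured step, an at least 2.2-fold lower number from compound 1 to compound 2 (0.34 log units; beyond the scatter), is the only reference available. Compound 3, `CC(C)n1nc(-c2ccc3oc(N)nc3c2)c2cnc(N)nc21`, has not yet been tested in this assay; it differs from compound 2 as follows: hydrogen in place of cyano on an aromatic carbon. Among the compounds with values here, no measured pair here exchanges cyano for hydrogen, so the measured step bears on this change only indirectly: it shows that the group at this position can shift the reading beyond the scatter. Compound 1, with its 11 uL/min, serves as the upper anchor. Compound 3 is expected to give 6 uL/min, within 3 uL/min to 14 uL/min. This estimate implies a step of an at least 1.2-fold higher number from compound 2 to compound 3 (0.07 log units; that floor lies within the scatter), with a fair chance that the assay again returns only a limit.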

Compound 3, intrinsic clearance in a liver preparation (reported as CLH), per the amount of preparation that the assay uses: 150 uL/min
For compound 3 the middle estimate is 25-fold (1.40 log units) below the measured one; measured number outside the range, above it.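

In this assay, the group on this aromatic carbon, next to the ring nitrogen, proves to matter far more than the earlier pair could show: hydrogen in place of cyano gives an at least 30-fold higher number from compound 2 to compound 3 (1.47 log units; beyond the scatter), and hydrogen in place of chloro gives a 14-fold higher number from compound 1 to compound 3 (1.13 log units; beyond the scatter). Until now only two substituents could be compared, whereas the two new steps show that both chloro and cyano stand far from hydrogen, and that compound 3 is removed fastest of the three compounds on the shared core. From the compounds shown here alone, the reading for compound 2 is a limit of the assay and not a number, so the true size of its step is unknown and the step gives only a floor: the limit of < 5 uL/min in this assay, at which 1 of the 3 values shown sits.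

The compounds shown leave open whether any group on this carbon would keep the number low, or whether that holds only for chloro and cyano, and a methyl, a methoxy, a fluoro or an amine would test this. They also give no measure of where on the molecule the removal takes place, so what lies behind the large steps remains unknown.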